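Shrinking the Amide Substituent on a Glutamate Receptor Modulator

The source may hold more compounds than are shown below. What is called first, only, known or untested is meant among the compounds shown, and "the series" means these compounds.

Of the compounds shown here, three sharing one core have been measured in an assay on HEK293 cells for positive allosteric modulation of metabotropic glutamate receptor 2 (Rattus norvegicus), read by thallium flux; a lower number here means that less compound is needed, a higher number that more compound is needed for the effect. Compound 1 `O=C(O)c1cc(-c2cccc(COc3ccc4c(c3)CN(CC3CC3)C4=O)c2)ccc1Cl` gives 80 nM, compound 2 `O=C(O)c1cc(-c2cccc(COc3ccc4c(c3)CN(c3ccccc3)C4=O)c2)ccc1Cl` gives 260 nM, and compound 3 `O=C(O)c1cc(-c2cccc(COc3ccc4c(c3)CN(Cc3ccc(C(F)(F)F)cc3)C4=O)c2)ccc1Cl` gives 350 nM, the highest of the three numbers. Compound 4 `CC(C)N1Cc2cc(OCc3cccc(-c4ccc(Cl)c(C(=O)O)c4)c3)ccc2C1=O` carries the change (isopropyl in place of 4-(trifluoromethyl)benzyl on an amide-type nitrogen in a ring). The step that bears most on this is a 4.4-fold higher number from compound 1 to compound 3 (0.64 log units; beyond the scatter), where compound 1 also carries a small saturated group on that nitrogen; the steps of a 3.3-fold higher number from compound 1 to compound 2 (0.51 log units; beyond the scatter) and a 1.3-fold higher number from compound 2 to compound 3 (0.13 log units; within the scatter) show that the two aromatic groups sit close together. A lower number is therefore expected for compound 4, roughly undoing that step, as a 3.5-fold lower number from compound 3 to compound 4 (0.54 log units; beyond the scatter). In this assay compound 4 is expected to give 100 nM, within a range from 40 nM to 250 nM.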

Compound 4, half-maximal effective concentration: 70 nM
Beside the measured number, compound 4's estimate is 1.4-fold (0.15 log units) above it; measured number inside the range.
By their numbers in this assay, from the lowest: compounds 4 and 1 (each within the scatter of the next); then compounds 2 and 3 (each within the scatter of the next).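

In this assay the isopropyl group performs on the amide-type nitrogen much as the cyclopropylmethyl group does, with a 1.1-fold lower number from compound 1 to compound 4 (0.06 log units; within the scatter), whereas the aromatic groups need more compound, as shown by a 5.0-fold lower number from compound 3 to compound 4 (0.70 log units; beyond the scatter) and a 3.7-fold lower number from compound 2 to compound 4 (0.57 log units; beyond the scatter). Among these four compounds, a second saturated group now joins the first, so the separation from the two aromatic groups no longer rests on compound 1 alone. Nothing available here explains this separation. As far as these compounds go, whether a methyl group, a cyclohexyl ring or a plain hydrogen on that nitrogen would give a similar number remains open.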